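Methoxy to Hydroxy at the Edge of Detection

This account rests on a few compounds, and the source may have more. Where it says the series, first, only, none or still open, it means among the compounds named here.

Measured compounds:
Compound 1, `Cc1cc(O)cc(-c2nn(CC#N)cc2-c2ccnc(-c3ccc(Oc4ccccc4)cc3)c2)c1`: 3970 nM
Compound 2, `COc1cc(C)cc(-c2nn(CC#N)cc2-c2ccnc(-c3ccc(N(C)C)cc3)c2)c1`: > 100000 nM

In a functional assay on NCI-H23 cells (Homo sapiens) for inhibition, read by sulforhodamine B assay, with a stated time of 48 h (on this read-out higher numbers stand for weaker inhibition of growth and lower numbers for stronger inhibition of growth), compound 1 gives 3970 nM. For compound 2 the result is only a limit of the assay, > 100000 nM, so that no number is known for it and it sits at the limit of > 100000 nM in this assay, at which 1 of the 2 values shown sits. Compound 2 is therefore the compound of the pair for which no growth inhibition could be quantified within the range tested.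

The unmeasured compound is compound 3, `Cc1cc(O)cc(-c2nn(CC#N)cc2-c2ccnc(-c3ccc(N(C)C)cc3)c2)c1`. It differs from compound 2 in one place: hydrogen in place of methyl on an oxygen on an aromatic ring, which reads methoxy to hydroxy. Within the data shown here, no pair differing in only this one place has been measured. No step size is recorded for it. Among the measured compounds shown here, compound 1 carries the same hydroxy group but a different aryl group, so its value shows only that a hydroxy compound on this core can give a measurable number.

Compound 3 is expected to lie at 60000 nM, within 10000 nM to 200000 nM. The expected step from compound 2 to compound 3 is an at least 1.6-fold lower number from compound 2 to compound 3 (0.22 log units; that floor lies within the scatter), a modest gain that may still leave the result at the limit.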

Compound 3, concentration for total growth inhibition: 24800 nM
Estimate against measurement, compound 3: 2.4-fold (0.38 log units) above; low and high end bracket the measured number.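

Among these compounds, with compound 3, the change from methoxy to hydroxy on the 3-methoxy-5-methylphenyl group can be read for the first time in this assay as an at least 4.0-fold lower number from compound 2 to compound 3 (0.60 log units; beyond the scatter), and the dimethylamino series now has a measured number. This size is only a floor, and the real step may be larger, because compound 2 is held only by a limit: the limit of > 100000 nM in this assay, at which 1 of the 3 values shown sits. Among the compounds shown here, compound 3 also allows the first comparison with the hydroxy group held constant, giving a 6.2-fold higher number from compound 1 to compound 3 (0.80 log units; beyond the scatter) when dimethylamino stands in place of phenoxy on an aromatic carbon, so the hydroxy group alone does not set the result and the group at that second place also counts.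

The compounds shown leave open whether methoxy to hydroxy moves the result in the same direction and by a similar amount when phenoxy is present, since this change rests on a single pair whose size has no upper bound. They also leave open how an ethoxy group or an amine at the same place on the aromatic ring would compare with the hydroxy group of compound 3 .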